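From butyl to isobutyl on the shared core

This account rests on a few compounds, and the source may have more. Where it says the series, first, only, none or still open, it means among the compounds named here.

Compound 1 `CCCn1ccnc1-c1cc(OC)c(OC)c(OC)c1` gives > 100000 nM (a limit)
Compound 2 `CCCCn1ccnc1-c1cc(OC)c(OC)c(OC)c1` gives > 100000 nM (a limit)

In a functional assay on HeLa cells (Homo sapiens) for antiproliferative activity, read by MTT assay, with a stated time of 72 h (on this read-out lower numbers stand for stronger inhibition and higher numbers for weaker inhibition), compound 2 stands at > 100000 nM as a limit and not as a number. For the measured compounds named here, the one other value, that of compound 1, is a limit too, so the record so far reads the limit of > 100000 nM in this assay, at which 2 of the 2 values shown sit, and nothing finer.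

Compound 3 `COc1cc(-c2nccn2CC(C)C)cc(OC)c1OC` has the same atoms as compound 2, joined differently. Counted out, isopropyl in place of propyl on a saturated chain carbon bound to an aromatic nitrogen is the difference; cut one bond further out, it reads butyl to isobutyl. Going by the values given here, the only measured step that bears on this change is a step that the two limits leave unreadable from compound 1 to compound 2 and it offers no size to carry over. No step beyond the scatter is therefore expected in this assay and no direction can be read, with compound 2 resting on its limit of > 100000 nM as the sole anchor. The estimate amounts to a number no higher from compound 2 to compound 3 (the limit leaves the size open) as an expected step and no more. Compound 3 is estimated at 100000 nM with an expected range from 40000 nM to 250000 nM and will probably be reported as a limit again.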

Compound 3, half-maximal inhibitory concentration: > 100000 nM
Compound 3: a limit, no number (the forecaster's own chance of this, stated with the estimate: 85%); the middle value lies on the limit itself.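

In this assay compound 3 gives > 100000 nM, a limit and not a number. The steps among compound 1, compound 2 and compound 3 therefore cannot be read, as all three values are limits. The compounds shown leave open whether changing the chain on the shared core alters antiproliferative activity at all.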